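A fluoro-to-methyl swap in a weakly inhibiting series

The source may report more compounds than this note shows. Statements on the series, on what has been measured and on what is new or still open speak of the compounds shown alone.

Compound 1 `CN(C)c1ccc(/C=C2/S/C(=N\c3nc4cc(-c5ccc(Cl)cc5)sc4s3)NC2=O)cc1` gives > 50000 nM which is a limit of the assay
Compound 2 `O=C1N/C(=N/c2nc3cc(-c4ccc(Cl)cc4)sc3s2)S/C1=C/c1ccc2ccccc2c1` gives 15200 nM
Compound 3 `O=C1N/C(=N/c2nc3cc(-c4ccc(Cl)cc4)sc3s2)S/C1=C/c1ccc(F)cc1` gives 21000 nM

Among the measured compounds shown here, in a functional assay on MCF7 cells (Homo sapiens) for inhibition, read by MTT assay, with a stated time of 72 h (a higher number here means a weaker inhibitor, a lower number a stronger inhibitor), compound 3 stands at 21000 nM with no clear gap to its only numeric neighbour. That step is a 1.4-fold higher number from compound 2 to compound 3 (0.14 log units; within the scatter) so the two cannot be ranked, as the difference is no larger than the normal spread between repeat measurements.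

Compound 4 `Cc1ccc(/C=C2/S/C(=N\c3nc4cc(-c5ccc(Cl)cc5)sc4s3)NC2=O)cc1` carries methyl in place of fluoro on an aromatic carbon, para to a large group, and methyl in place of fluoro on an aromatic carbon is the whole change. For the measured compounds named here, no measured step makes this exact swap. The closest evidence is an at least 2.3-fold lower number from compound 1 to compound 3 (0.37 log units; beyond the scatter) together with an at least 3.2-fold lower number from compound 1 to compound 2 (0.51 log units; beyond the scatter) and both of these start from a limit, so they fix only a minimum size. Since a 1.4-fold higher number from compound 2 to compound 3 (0.14 log units; within the scatter) stayed within the scatter even with 4-fluorophenyl in place of naphthalen-2-yl, this smaller change is not expected to do more. In this assay no step beyond the scatter is therefore expected, in either direction (estimated: a 1.0-fold higher number from compound 3 to compound 4 (0.02 log units; within the scatter)). Compound 4 is estimated at 22000 nM (expected range 11000 nM to 45000 nM).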

Compound 4, half-maximal inhibitory concentration: 3300 nM
Beside the measured number, compound 4's estimate is 6.7-fold (0.82 log units) above it, outside the stated range (below it).
By their numbers in this assay, from the lowest: compound 4; then compounds 2 and 3 (each within the scatter of the next). At a limit, above all of these: compound 1.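

In this assay, the position on the aromatic carbon para to a large group proves sensitive to a change of one heavy atom, with no ring, hydrogen-bond donor or acceptor entering or leaving: methyl in place of fluoro gives a 6.4-fold lower number from compound 3 to compound 4 (0.80 log units; beyond the scatter) in this series. The earlier pair with measured numbers could not be ranked, yet 4-methylphenyl in place of naphthalen-2-yl gives a 4.6-fold lower number from compound 2 to compound 4 (0.66 log units; beyond the scatter) and so separates compound 4 from both of them. Compound 1 stands at a limit, so an at least 15-fold lower number from compound 1 to compound 4 (1.18 log units; beyond the scatter) fixes only a minimum size for methyl in place of dimethylamino: the limit of > 50000 nM in this assay, at which 1 of the 4 values shown sits.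

The compounds shown leave open whether this response belongs to methyl alone or would also appear with ethyl, a longer chain, methoxy or chloro at the same position. They also leave open why so small a swap moves the number in this cell assay, and whether the same swap would have a similar effect on a core other than the one shared here.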